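From Ethyl to Cyclopropyl: An Estimate for Compound 3

The source may hold more compounds than are shown below. What is called first, only, known or untested is meant among the compounds shown, and "the series" means these compounds.

Within the data shown here, only two compounds have been measured so far in an ADME assay on S9 fraction from liver (Homo sapiens) for metabolic stability, read by LC-MS, using NADPH, with stated times of 5 min and 60 min, tested at 5 uM; on this read-out higher numbers stand for a more stable compound and lower numbers for a less stable compound. Of these, compound 1 (`COc1cc(C2CN(C(=O)c3cc(OCCCC(C)(C)C(=O)O)ccn3)C2)ccc1OCc1ccc(C2CC2)cc1`) gives 81%. The other, compound 2 (`CCc1ccc(COc2ccc(C3CN(C(=O)c4cc(COCC(CO)(CO)CO)ccn4)C3)cc2OC)cc1`), gives 61%, which is the lower of the two numbers, and the gap between them lies beyond the usual scatter of repeated measurements.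

Compound 3 (`COc1cc(C2CN(C(=O)c3cc(COCC(CO)(CO)CO)ccn3)C2)ccc1OCc1ccc(C2CC2)cc1`) has not yet been measured and differs from compound 2 in one place: cyclopropyl in place of ethyl on an aromatic carbon. Put simply, cyclopropyl stands in place of ethyl on an aromatic carbon, para to a large group. The two measured compounds do not form a pair that differs in one place, so the data give no direct reading of what this exchange does in this assay.

The estimate therefore starts from compound 2 at 61% and favours neither direction. The expected change a number 1 percentage points lower from compound 2 to compound 3 (within the scatter) is estimated to stay within the usual scatter. Compound 3 is expected to give 60%, with an estimated range of 44% to 76%.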

Compound 3, percent of the compound remaining in the Homo sapiens assay: 85%
For compound 3 the middle estimate is 25 percentage points below the measured one; the measured number lies above the stated range.
By their numbers in the Homo sapiens assay, from the lowest: compound 2; then compounds 1 and 3 (each within the scatter of the next).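

Among these compounds, with the side chain held constant, exchanging ethyl for cyclopropyl on the aromatic carbon in the Homo sapiens assay takes compound 2 at 61% to compound 3 at 85%; this gives a number 24 percentage points higher from compound 2 to compound 3 (beyond the scatter) and so provides the first direct reading of this change, which turns out to exceed the usual scatter at this position. In a physicochemical assay for solubility, in phosphate buffer, at pH 7.2 (a higher number here means a more soluble compound, a lower number a less soluble compound), compound 2 gives 2800 nM and compound 3 gives 1500 nM; the same exchange gives a 1.9-fold lower number from compound 2 to compound 3 (0.27 log units; within the scatter) and therefore does not separate the two compounds on solubility. With the 4-cyclopropylbenzyl part held constant, replacing (4-carboxy-4-methylpentyl)oxy with (3-hydroxy-2,2-bis(hydroxymethyl)propoxy)methyl in the Homo sapiens assay gives a number 4 percentage points higher from compound 1 to compound 3 (within the scatter) and thus leaves the two chains unseparated on this read-out, so the ethyl-to-cyclopropyl step stands out as the clearer difference among the pairs shown.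

Nothing available here explains the step seen with cyclopropyl. The compounds shown leave open how isopropyl or cyclobutyl would read at this same aromatic carbon, and whether ethyl and cyclopropyl would differ to a similar extent on a compound carrying the (4-carboxy-4-methylpentyl)oxy chain.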